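This account rests on a few compounds, and the source may have more. Where it says the series, first, only, none or still open, it means among the compounds named here.

Going by the values given here, compound 2, `C=C1[C@@H](OC(C)=O)C[C@@H]2[C@](C)(COC=O)[C@H](OC(C)=O)CC[C@@]2(C)[C@@H]1C[C@@H](Nc1cccc(F)c1)C1=CCOC1=O`, is the only member of the series with a number rather than a limit: in a functional assay on KB cells (Homo sapiens) for cytotoxicity, read by sulforhodamine B assay (on this read-out lower numbers stand for stronger inhibition and higher numbers for weaker inhibition), compound 2 gives 28600 nM. Compound 1, `C=C1[C@@H](OC(C)=O)C[C@@H]2[C@](C)(COC=O)[C@H](OC(C)=O)CC[C@@]2(C)[C@@H]1C[C@@H](Nc1ccc(C(=O)O)cc1)C1=CCOC1=O`, stands at a limit of this assay, giving > 50000 nM. Among the compounds with values here, the one measured step, an at least 1.7-fold lower number from compound 1 to compound 2 (0.24 log units; that floor lies within the scatter), is therefore only a floor, since compound 1 sits at the limit of > 50000 nM in this assay, at which 1 of the 2 values shown sits.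

Compound 3, `C=C1[C@@H](OC(C)=O)C[C@@H]2[C@](C)(COC=O)[C@H](OC(C)=O)CC[C@@]2(C)[C@@H]1C[C@@H](Nc1ccc(F)cc1)C1=CCOC1=O`, differs from compound 2 by 4-fluorophenyl in place of 3-fluorophenyl on an amine nitrogen. Within the data shown here, no measured step moves a fluorine on the phenyl ring; the only step known swaps a 4-carboxyphenyl for a 3-fluorophenyl, and its floor lies within the scatter. For this assay the expectation is a step of about a 1.0-fold higher number from compound 2 to compound 3 (0.02 log units; within the scatter), that is, no change beyond the scatter in either direction. Compound 3 is estimated at 30000 nM, with a range from 10000 nM to 80000 nM, and a fair chance that this assay again reports only a limit.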

Compound 3, half-maximal inhibitory concentration: 22900 nM
For compound 3 the middle estimate is 1.3-fold (0.12 log units) above the measured one, within the range that was stated.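

In this assay, moving the fluorine gives a 1.2-fold lower number from compound 2 to compound 3 (0.10 log units; within the scatter), so 3-fluorophenyl and 4-fluorophenyl on the amine nitrogen are not told apart on this read-out. Fluoro in place of carboxy at the same ring carbon now gives a step that clears the scatter, which the 3-fluorophenyl comparison could not show: an at least 2.1-fold lower number from compound 1 to compound 3 (0.33 log units; beyond the scatter). That step is a floor rather than a measured size, because compound 1 stands at a limit of the assay: the limit of > 50000 nM in this assay, at which 1 of the 3 values shown sits.

On these data alone, the true distance between compound 1 and compound 3 stays open, as does whether any fluorine is needed at all. An unsubstituted phenyl, a 4-chlorophenyl, a 4-methoxyphenyl or a 4-aminophenyl on the same amine nitrogen could each answer that, and none of them can be judged from the compounds shown.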